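A Methoxy Step Repeated on a Second Core

The source may report more compounds than this note shows. Statements on the series, on what has been measured and on what is new or still open speak of the compounds shown alone.

Compound 1 `CC(=O)Nc1ccc2oc(-c3ccccc3)cc(=O)c2c1` gives 184000 nM in an ADME assay on MT4 cells (Homo sapiens) for cytotoxicity, read by MTT assay, with a stated time of 4 days; on this read-out lower numbers stand for higher toxicity in this test and higher numbers for lower toxicity in this test. Compound 2 `COc1ccccc1-c1cc(=O)c2cc(NC(C)=O)ccc2o1` carries methoxy in place of hydrogen on an aromatic carbon and gives 226000 nM in this assay, a step of a 1.2-fold higher number from compound 1 to compound 2 (0.09 log units; within the scatter). Compound 3 `Nc1ccc2oc(-c3ccccc3)c(O)c(=O)c2c1` gives 217000 nM in this assay; the difference between its core and the core of compound 1 is not broken down here. Compound 4 `COc1cccc(-c2oc3ccc(N)cc3c(=O)c2O)c1` is not yet measured and differs from compound 3 by methoxy in place of hydrogen on an aromatic carbon. This is the same kind of change as that from compound 1 to compound 2, though there the methoxy sits ortho to a large group and here meta to a large group. Because a 1.2-fold higher number from compound 1 to compound 2 (0.09 log units; within the scatter) lies within the scatter, the expected step for compound 4 is a 1.1-fold higher number from compound 3 to compound 4 (0.03 log units; within the scatter). Compound 4 is estimated at 230000 nM, with a range from 120000 nM to 420000 nM.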

Compound 4, half-maximal cytotoxic concentration: 40800 nM
The estimate for compound 4 lay 5.6-fold (0.75 log units) above the measured number; the measured number lies below the stated range.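

In this assay, methoxy in place of hydrogen on an aromatic carbon gave a 5.3-fold lower number from compound 3 to compound 4 (0.73 log units; beyond the scatter), and the step seen on the core of compound 1 did not carry over to this second core: the same change on two cores in this assay, a 1.2-fold higher number (0.09 log units; within the scatter) from compound 1 to compound 2 and a 5.3-fold lower number (0.73 log units; beyond the scatter) from compound 3 to compound 4, 6.5-fold (0.82 log units) apart, beyond the scatter of two such steps This shows that, among these two pairs, the step from one core cannot be taken as the step on the other. It does not show that the core alone sets the size of the step, since the methoxy in compound 4 sits meta to a large group and the two pairs differ in that place as well.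

The compounds shown leave open what the methoxy would do at this same place on the core of compound 1. They also leave open whether an ethoxy group or a chlorine atom there would follow compound 4.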